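The source may hold more compounds than are shown below. What is called first, only, known or untested is meant among the compounds shown, and "the series" means these compounds.

Measured compounds:
Compound 1, `NC1(CCn2ccc(=O)[nH]c2=O)OC(=O)C(OCc2ccccc2)=C1OCc1ccccc1` — > 100000 nM (a limit of the assay, not a number).
Compound 2, `O=C1O/C(=C\Cn2ccc(NC(=O)c3ccccc3)nc2=O)C(OCc2ccccc2)=C1OCc1ccccc1` — 7200 nM.
Compound 3, `O=C1O/C(=C\Cn2ncc(=O)[nH]c2=O)C(OCc2ccccc2)=C1OCc1ccccc1` — 45000 nM.

All three were tested in a functional assay on HeLa cells (Homo sapiens) for inhibition, read by MTT assay, with a stated time of 72 h; a lower number here means a stronger inhibitor, a higher number a weaker inhibitor. Compound 2 gives 7200 nM and compound 3 gives 45000 nM. For compound 1 the assay returns no number, only a limit, > 100000 nM. Compound 1 therefore stands at the limit of > 100000 nM in this assay, at which 1 of the 3 values shown sits, with no measurable inhibition in this assay. Compound 4, `Cc1cn(CCC2(N)OC(=O)C(OCc3ccccc3)=C2OCc2ccccc2)c(=O)[nH]c1=O`, has not yet been measured. It differs from compound 1 in one place: methyl in place of hydrogen on an aromatic carbon. For the measured compounds named here, no pair of measured compounds differing in a single place is available here, so the size of such a step cannot be read off from measured data. Starting from a compound that already sits at the limit, a single methyl is expected to change little. The estimated step is a number no higher from compound 1 to compound 4 (the limit leaves the size open), that is no change beyond the usual scatter. In this assay compound 4 is expected to give 100000 nM, within 30000 nM to 300000 nM, most likely again reported only as a limit.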

Compound 4, half-maximal inhibitory concentration: > 100000 nM
Compound 4 was reported as a limit (the forecaster's own chance of this, stated with the estimate: 75%); the middle value sits exactly at the limit.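

For the compounds shown here, compound 1 and compound 4 each give only a limit, not a number, and no step between them can be read: the limit of > 100000 nM in this assay, at which 2 of the 4 values shown sit. The compounds shown leave open whether methyl in place of hydrogen on an aromatic carbon changes inhibition at all.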